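A few compounds are considered here, and "the series" means these few. Any claim that something is new, unique, unknown or untested is made for them only; others in the source may bear on it.

Measured in a functional assay on MOLT-3 cells (Homo sapiens) for cytotoxicity, read by MTT assay, with a stated time of 48 h; a higher number here means a weaker inhibitor, a lower number a stronger inhibitor:

- Compound 1 `COc1cc2c(cc1OC)CN(S(=O)(=O)c1ccc(-n3cc(COc4ccccc4C(C)=O)nn3)cc1)CC2`: > 50 ug/mL (a limit)
- Compound 2 `Cc1ccccc1OCc1cn(-c2ccc(S(=O)(=O)N3CCc4ccccc4C3)cc2)nn1`: > 50 ug/mL (a limit)
- Compound 3 `O=S(=O)(c1ccc(-n2cc(COc3ccccc3)nn2)cc1)N1CCc2ccccc2C1`: > 50 ug/mL (a limit)

The picture so far is simple: the limit of > 50 ug/mL in this assay, at which 3 of the 3 values shown sit. Compound 3 therefore has no number, and > 50 ug/mL is only a limit. Compound 4 `O=S(=O)(c1ccc(-n2cc(CO)nn2)cc1)N1CCc2ccccc2C1` is related to it by one structural change: hydrogen in place of phenyl on an oxygen on a saturated carbon. In words, hydrogen replaces phenyl on an oxygen on a saturated carbon, turning phenoxymethyl into hydroxymethyl.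

Going by the values given here, the one measured step, a step that the two limits leave unreadable from compound 2 to compound 3, concerns a different change, hydrogen in place of methyl on an aromatic carbon. It offers no size to carry over, so no shift in either direction beyond the scatter is expected in this assay. The expected step is a number no higher from compound 3 to compound 4 (the limit leaves the size open), an estimate with no measured direction behind it. The estimate for compound 4 is 50 ug/mL, expected to lie from 20 ug/mL to 120 ug/mL.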

Compound 4, half-maximal inhibitory concentration: > 50 ug/mL
Compound 4: no number, only a limit (the forecaster's own chance of this, stated with the estimate: 70%); the middle value lies on the limit itself.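

Compound 4 gives > 50 ug/mL as a limit and not a number. The steps to compound 4 from compound 2 and from compound 3 therefore cannot be read. Still open is whether any of these compounds has a measurable potency in this assay, and whether any of these changes alters it: the limit of > 50 ug/mL in this assay, at which 4 of the 4 values shown sit.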